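Sulfur-linked side chain changes in a receptor antagonist series

The source may report more compounds than this note shows. Statements on the series, on what has been measured and on what is new or still open speak of the compounds shown alone.

Measured so far in an assay on CHO-K1 cells for antagonist activity at transient receptor potential cation channel subfamily V member 1 (Homo sapiens), read by FLIPR; a lower number here means a stronger inhibitor, a higher number a weaker inhibitor:
compound 1, `CC1CCC(Sc2nc(C(F)(F)F)ccc2CNC(=O)C(C)c2ccc(NS(C)(=O)=O)c(F)c2)CC1`, gives 0.5 nM
compound 2, `CC(C(=O)NCc1ccc(C(F)(F)F)nc1SCc1ccc(Cl)cc1)c1ccc(NS(C)(=O)=O)c(F)c1`, gives 8.7 nM
compound 3, `Cc1ccc(CSc2nc(C(F)(F)F)ccc2CNC(=O)C(C)c2ccc(NS(C)(=O)=O)c(F)c2)cc1`, gives 3.2 nM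

Compound 3 stands second highest of the three numbers in this assay; its nearest neighbour is compound 2 (a 2.7-fold lower number from compound 2 to compound 3 (0.43 log units; beyond the scatter)) and its furthest is compound 1 (a 6.4-fold higher number from compound 1 to compound 3 (0.81 log units; beyond the scatter)). Compound 4, `CC(C(=O)NCc1ccc(C(F)(F)F)nc1SCCc1ccccc1)c1ccc(NS(C)(=O)=O)c(F)c1`, has not been measured. It differs from compound 3 by benzyl in place of 4-methylphenyl on a saturated chain carbon bound to a sulfur.

Going by the values given here, no measured step addresses moving a methyl from the aromatic ring into the chain on the sulfur. The closest bearing steps are the change of the aromatic substituent (a 2.7-fold lower number from compound 2 to compound 3 (0.43 log units; beyond the scatter), modest) and the exchange of the whole group on the sulfur (a 17-fold higher number from compound 1 to compound 2 (1.24 log units; beyond the scatter), large; a 6.4-fold higher number from compound 1 to compound 3 (0.81 log units; beyond the scatter), modest). Those steps show that the group on the sulfur matters and that a small change there tends to give a modest step. For compound 4 a modest rise in number is therefore expected, a 1.9-fold higher number from compound 3 to compound 4 (0.27 log units; within the scatter). Compound 4 is estimated at 6 nM, with a range from 2 nM to 20 nM.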

Compound 4, inhibition constant: 1.9 nM
The estimate for compound 4 lay 3.2-fold (0.50 log units) above the measured number; measured number below the stated range.
By their numbers in this assay, from the lowest: compound 1; then compounds 4 and 3 (each within the scatter of the next); then compound 2.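

In this assay, moving the methyl carbon from the ring into the chain on the sulfur, 4-methylbenzyl to phenethyl, gives a difference within the scatter (a 1.7-fold lower number from compound 3 to compound 4 (0.23 log units; within the scatter)), so this position does not separate these two arrangements of the same atoms. Phenethyl keeps a clear margin over the 4-chlorobenzyl group (a 4.6-fold lower number from compound 2 to compound 4 (0.66 log units; beyond the scatter)) but leaves a gap to 4-methylcyclohexyl (a 3.8-fold higher number from compound 1 to compound 4 (0.58 log units; beyond the scatter)), and compound 1 remains the lowest number of the four. Nothing shown gives a reason for these differences.

The compounds shown leave open how a longer chain, such as 3-phenylpropyl, would read on the sulfur, and whether cyclohexylmethyl or cyclohexylethyl would hold the level of compound 1. From the compounds shown here alone, an amine or a carboxylic acid on the group on the sulfur also remains open.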